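Working notes: from 3-chlorobenzyl to 2-fluorobenzyl

The source may report more compounds than this note shows. Statements on the series, on what has been measured and on what is new or still open speak of the compounds shown alone.

Measured in a functional assay on K562 cells (Homo sapiens) for cytotoxicity, read by MTT assay, with a stated time of 48 h; a lower number here means a stronger inhibitor, a higher number a weaker inhibitor:
- compound 1 `Cc1cccc(CN2CCN(C(=O)CN[C@H]3CCN(S(=O)(=O)Cc4ccccc4)C3)CC2)c1`: 11300 nM
- compound 2 `O=C(CN[C@H]1CCN(S(=O)(=O)Cc2ccccc2)C1)N1CCN(Cc2cccc(Cl)c2)CC1`: 8600 nM

In this assay, among the compounds with values here, compound 2 gives 8600 nM, and it cannot be separated from compound 1, the only other measured compound. The next structure is compound 3 `O=C(CN[C@H]1CCN(S(=O)(=O)Cc2ccccc2)C1)N1CCN(Cc2ccccc2F)CC1`, which carries 2-fluorophenyl in place of 3-chlorophenyl on a saturated chain carbon bound to an amine nitrogen in a ring. Read one bond further out, this is 3-chlorobenzyl to 2-fluorobenzyl.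

Within the data shown here, one measured step bears on this change: a 1.3-fold lower number from compound 1 to compound 2 (0.12 log units; within the scatter). That step swapped methyl for chloro on an aromatic carbon and left the rest of the structure untouched. Among the measured compounds shown here, no measured compound carries fluoro, and none shows what moving the substituent does, so the evidence is thin. For the measured compounds named here, the one precedent gives no reason to expect movement beyond the scatter, and no direction can be assigned.

The estimated step is a 1.0-fold higher number from compound 2 to compound 3 (0.02 log units; within the scatter), which is not expected to exceed the scatter. For compound 3 the expected value in this assay is 9000 nM, with an estimated range of 4000 nM to 20000 nM.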

Compound 3, half-maximal inhibitory concentration: 12600 nM
For compound 3 the middle estimate is 1.4-fold (0.15 log units) below the measured one; measured number inside the range.
By their numbers in this assay, from the lowest: compounds 2, 1 and 3 (each within the scatter of the next).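

In this assay, 2-fluorophenyl in place of 3-chlorophenyl on a saturated chain carbon bound to an amine nitrogen in a ring gives a 1.5-fold higher number from compound 2 to compound 3 (0.17 log units; within the scatter), and 2-fluorophenyl in place of 3-methylphenyl gives a 1.1-fold higher number from compound 1 to compound 3 (0.05 log units; within the scatter). The earlier compounds shown here covered only an exchange of methyl for chloro with the substituent's place on the phenyl ring unchanged, whereas these steps change both the substituent and its place, and the number still does not leave the scatter, so 3-methylbenzyl, 3-chlorobenzyl and 2-fluorobenzyl cannot be told apart. No measurement at hand accounts for this flat reading.

The step from compound 2 to compound 3 changes the halogen and its place together, so the contribution of each on its own remains unresolved. Also open, from the compounds shown here alone, is whether a group of a different kind at this position, such as a carboxylic acid or an amine on the phenyl ring, or a longer chain in place of the benzyl link, would move the number beyond the scatter.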